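Replacing naphthalen-2-yl with 4-(trifluoromethyl)phenyl

This account rests on a few compounds, and the source may have more. Where it says the series, first, only, none or still open, it means among the compounds named here.

In an ADME assay on BJ cells (Homo sapiens) for cytotoxicity, with a stated time of 72 h (a higher number here means that more compound is needed for the effect, a lower number that less compound is needed), compound 1 (`Cc1ccc(-c2nc3c(c(C)nn3-c3ccccc3)c(-c3ccccc3O)c2C#N)cc1`) gives 22200 nM as a true measured number. Compound 2 (`Cc1nn(-c2ccccc2)c2nc(-c3ccc4ccccc4c3)c(C#N)c(-c3ccccc3O)c12`) reads > 20000 nM and this is a limit, not a number. So the only measured step (a step that the limit leaves unreadable from compound 1 to compound 2) has no size to carry forward. Also worth keeping in view is the limit of > 20000 nM in this assay, at which 1 of the 2 values shown sits, and compound 3 could end up there too.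

Compound 3 (`Cc1nn(-c2ccccc2)c2nc(-c3ccc(C(F)(F)F)cc3)c(C#N)c(-c3ccccc3O)c12`) carries 4-(trifluoromethyl)phenyl in place of naphthalen-2-yl on an aromatic carbon. Going by the values given here, the only firm number nearby is that of compound 1 at 22200 nM so a value in the same region is expected, and no clear direction can be foreseen. The estimated step is a step that the limit leaves unreadable from compound 2 to compound 3 and it is expected to stay within the usual scatter. The estimated value for compound 3 is 21000 nM (expected range 9000 nM to 40000 nM).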

Compound 3, half-maximal effective concentration: 22900 nM
The estimate for compound 3 lay 1.1-fold (0.04 log units) below the measured number, and the stated range covers the measured number.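

In this assay, going by these compounds alone, trifluoromethyl in place of methyl on the phenyl ring gives a 1.0-fold higher number from compound 1 to compound 3 (0.01 log units; within the scatter), the first step at this position whose size can be read. Within this pair, the change from 4-methylphenyl to 4-(trifluoromethyl)phenyl therefore leaves the cytotoxicity read-out within the usual scatter. The steps to and from compound 2 cannot be read, as its value is a limit and not a number: the limit of > 20000 nM in this assay, at which 1 of the 3 values shown sits.

Still open, on these data alone, is whether an amine or a carboxylic acid on this phenyl ring would move the number beyond the scatter. The compounds shown also leave open how the read-out would respond to replacing the whole aromatic group at this position with a short alkyl chain.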